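This account rests on a few compounds, and the source may have more. Where it says the series, first, only, none or still open, it means among the compounds named here.

Measured so far in an assay on cells for inhibition of HSP60/HSP10 (Homo sapiens), with a stated time of 60 min; on this read-out lower numbers stand for stronger inhibition and higher numbers for weaker inhibition:

compound 1, `O=S(=O)(Nc1ccc(-c2nc3cc(NS(=O)(=O)c4ccccc4)ccc3o2)cc1)c1ccccc1`: 80000 nM
compound 2, `O=S(=O)(Nc1ccc2oc(-c3ccccc3)nc2c1)c1cccc(F)c1`: > 100000 nM

Compound 1 gives a number, and at 80000 nM compound 1 is only a weak inhibitor on this read-out. Compound 2 gives no number in this assay: its value of > 100000 nM is a limit of the assay. Compound 2 therefore sits at the limit of > 100000 nM in this assay, at which 1 of the 2 values shown sits, and where compound 2 stands on the numbers is known only as a limit, so the gap between compound 1 and compound 2 cannot be sized from what is shown.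

Compound 3, `O=S(=O)(Nc1ccc2oc(-c3ccccc3)nc2c1)c1cccc(O)c1`, differs from compound 2 in one place: hydroxy in place of fluoro on an aromatic carbon. Among the compounds with values here, no pair of measured compounds differing in one place is available, so the effect of any single change has not yet been sized.

For compound 3 the expected step is a number no higher from compound 2 to compound 3 (the limit leaves the size open), that is, none beyond the usual scatter of this assay. Compound 3 is therefore estimated at 100000 nM, in the range 30000 nM to 300000 nM, with a real chance that this assay again reports only a limit for compound 3.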

Compound 3, half-maximal inhibitory concentration: 76000 nM
Beside the measured number, compound 3's estimate is 1.3-fold (0.12 log units) above it; low and high end bracket the measured number.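

In this assay, within the data shown here, the change from 3-fluorophenyl to 3-hydroxyphenyl is the first single change that can be read at all, and it gives an at least 1.3-fold lower number from compound 2 to compound 3 (0.11 log units; that floor lies within the scatter). With hydroxy on this aromatic carbon, meta to a large group, compound 3 returns a number, 76000 nM, so this position can carry a hydroxy group and still give a measurable, though weak, read-out. Compound 2 stands at > 100000 nM, which is a limit and not a number, so this step has only a floor and its true size stays unknown because one end of it is a limit: the limit of > 100000 nM in this assay, at which 1 of the 3 values shown sits.

As far as these compounds go, whether a different group at this position, such as an amine, a methoxy group or a carboxylic acid, would shift the number beyond the usual scatter remains open. Also open is whether the hydroxy group would give a similar reading at another place on this ring, since the compounds shown carry it at only this one position.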